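The source may hold more compounds than are shown below. What is called first, only, known or untested is meant among the compounds shown, and "the series" means these compounds.

- compound 1 `Cc1cc(Nc2cc(-c3ccccc3)[nH]n2)n2nc(SCC3CCCCC3)nc2n1` gives > 50000 nM (a limit)
- compound 2 `Cc1cc(Nc2cc(-c3ccccc3)[nH]n2)n2nc(SCc3nc4ccccc4[nH]3)nc2n1` gives 27800 nM
- compound 3 `Cc1ccc(CSc2nc3nc(C)cc(Nc4cc(-c5ccccc5)[nH]n4)n3n2)cc1` is not yet measured

Among the measured compounds shown here, in an ADME assay on GES1 cells (Homo sapiens) for inhibition, read by MTT assay, with a stated time of 72 h (on this read-out lower numbers stand for stronger inhibition and higher numbers for weaker inhibition), compound 2 gives 27800 nM as the only actual number so far. Compound 1 gives > 50000 nM as a limit of the assay. Compound 3 differs from compound 2 as follows: 4-methylphenyl in place of 1H-benzimidazol-2-yl on a saturated chain carbon bound to a sulfur with 4-methylphenyl in place of 1H-benzimidazol-2-yl on a saturated chain carbon bound to a sulfur. With only an at least 1.7-fold lower number from compound 1 to compound 2 (0.25 log units; that floor lies within the scatter) to go on at this place, no step beyond the scatter is expected in this assay for this change. Compound 3 is estimated at 35000 nM within an expected range from 15000 nM to 70000 nM in this assay. That estimate means an expected 1.3-fold higher number from compound 2 to compound 3 (0.10 log units; within the scatter) and no more.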

Compound 3, half-maximal inhibitory concentration: 36200 nM
Beside the measured number, compound 3's estimate is 1.0-fold (0.01 log units) below it; the range from low to high includes it.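

In this assay, 4-methylphenyl in place of 1H-benzimidazol-2-yl on a saturated chain carbon bound to a sulfur gives a 1.3-fold higher number from compound 2 to compound 3 (0.11 log units; within the scatter), so this change, which removes the hydrogen-bond donor and acceptor counted for the leaving group, shows no step beyond the scatter. 4-Methylphenyl in place of cyclohexyl gives an at least 1.3-fold lower number from compound 1 to compound 3 (0.14 log units; that floor lies within the scatter), which is only a floor, and the value of compound 1 is a limit of the assay: the limit of > 50000 nM in this assay, at which 1 of the 3 values shown sits. The compounds shown leave open whether an amine, a carboxylic acid or a longer chain at this place would move the number beyond the scatter.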